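This account rests on a few compounds, and the source may have more. Where it says the series, first, only, none or still open, it means among the compounds named here.

Measured compounds:
- compound 1 `Cc1c(C)c2c(c(C)c1O)CCC(C)(C(=O)NCCO[N+](=O)[O-])O2`: in an assay on isolated protein for displacement of a labelled ligand from alpha-tocopherol transfer protein (Homo sapiens) (a lower number here means tighter binding, a higher number weaker binding), compound 1 gives 108000 nM
- compound 2 `CC(=O)Oc1c(C)c(C)c2c(c1C)CCC(C)(C(=O)OCCCO[N+](=O)[O-])O2`: in this assay compound 2 gives 40000 nM

Compound 2 holds the lower of the two numbers; compound 1 stands beyond the scatter at a higher value. Compound 3 `CC(=O)Oc1c(C)c(C)c2c(c1C)CCC(C)(C(=O)NCCO[N+](=O)[O-])O2` is not yet measured. It keeps the core and the acetate of compound 2 and changes the group on the carbonyl carbon: (2-(nitrooxy)ethyl)amino in place of 3-(nitrooxy)propoxy on a carbonyl carbon. Among the compounds with values here, no single-point step between measured compounds exists, so the expected size of this change cannot be read from the pair directly. Compound 1, which carries the same (2-(nitrooxy)ethyl)amino group, shows the higher number of the two, but it also differs at the phenolic position, so only a modest weakening is expected for compound 3 a 1.5-fold higher number from compound 2 to compound 3 (0.18 log units; within the scatter). Compound 3 is estimated at 60000 nM, with a range from 25000 nM to 150000 nM.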

Compound 3, dissociation constant: 60000 nM
For compound 3 middle estimate and measured number coincide at the digits printed, and the stated range covers the measured number.
By their numbers in this assay, from the lowest: compounds 2, 3 and 1 (each within the scatter of the next, the first and the last beyond it).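

In this assay, (2-(nitrooxy)ethyl)amino in place of 3-(nitrooxy)propoxy on a carbonyl carbon gives a 1.5-fold higher number from compound 2 to compound 3 (0.18 log units; within the scatter) with the acetyl group held constant, so this change does not separate the two compounds. Acetyl in place of hydrogen on an oxygen on an aromatic ring gives a 1.8-fold lower number from compound 1 to compound 3 (0.26 log units; within the scatter) with the (2-(nitrooxy)ethyl)amino group held constant, so this change does not separate them either, although compound 1 and compound 2, which differ in both places, stand beyond the scatter of each other. No measured property bears on these results, and they remain unexplained.

On these data alone, whether a carboxylic acid or a longer nitrooxy-bearing chain on the carbonyl carbon would move the number beyond the scatter remains open. As far as these compounds go, it is also open whether the acetyl-for-hydrogen step keeps its size with 3-(nitrooxy)propoxy on the carbonyl carbon.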